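The compounds below may be only part of what the source reports. "The series", "measured", "known", "first", "only" and "open" are said of these compounds alone.

Three carbamates sharing one core have been measured in an ADME assay on BEAS-2B cells (Homo sapiens) for cytotoxicity, read by MTT assay, with a stated time of 72 h; a lower number here means a stronger inhibitor of growth, a higher number a weaker inhibitor of growth. Compound 1 `C=CCOC(=O)Nc1ccc([Se]C#N)cc1` gives 21400 nM, and compound 2 `CCCOC(=O)Nc1ccc([Se]C#N)cc1` gives 19200 nM, the two differing by a 1.1-fold lower number from compound 1 to compound 2 (0.05 log units; within the scatter). Compound 3 `N#C[Se]c1ccc(NC(=O)OCc2ccccc2)cc1` gives 100 nM, the lowest of the three numbers, separated from the others by a 210-fold lower number from compound 1 to compound 3 (2.33 log units; beyond the scatter) and by a 190-fold lower number from compound 2 to compound 3 (2.28 log units; beyond the scatter). Compound 4 `CCOC(=O)Nc1ccc([Se]C#N)cc1` is the next member; from compound 3 it differs as follows: methyl in place of phenyl on a saturated chain carbon bound to an oxygen next to a carbonyl group. This undoes the change that set compound 3 apart, so the two large steps from compound 1 and compound 2 to compound 3 are the ones that bear on it, and a rise of similar size back towards the numbers of compounds 1 and 2 is expected. Compound 4 is therefore estimated at 20000 nM, within 6000 nM to 60000 nM, an expected step of a 200-fold higher number from compound 3 to compound 4 (2.30 log units; beyond the scatter).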

Compound 4, concentration for 50% growth inhibition: 21700 nM
For compound 4 the middle estimate is 1.1-fold (0.04 log units) below the measured one; low and high end bracket the measured number.
By their numbers in this assay, from the lowest: compound 3; then compounds 2, 1 and 4 (each within the scatter of the next).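

Methyl in place of phenyl gives a 220-fold higher number from compound 3 to compound 4 (2.34 log units; beyond the scatter), so the large step is seen again with a third small group, and in this assay compound 3 alone stands apart. The smaller groups cannot be told apart: the pairs show a 1.1-fold higher number from compound 2 to compound 4 (0.05 log units; within the scatter) and a 1.0-fold higher number from compound 1 to compound 4 (0.01 log units; within the scatter), so methyl, ethyl and vinyl in this place behave alike. Nothing available accounts for the gap to phenyl. On these data alone, whether a cyclohexyl ring or a methoxy-bearing phenyl in this place would match compound 3 or compound 4 remains open.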